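A few compounds are considered here, and "the series" means these few. Any claim that something is new, unique, unknown or untested is made for them only; others in the source may bear on it.

Among the compounds with values here, compound 1 `COc1cc(-c2cc(/C=C/C(=O)c3ccc(Cl)c(Cl)c3)[nH]n2)cc(OC)c1OC` stands highest of the two numbers so far: in a functional assay on SW-620 cells (Homo sapiens) for cytotoxicity, read by sulforhodamine B assay, with a stated time of 48 h, tested at 1 uM (on this read-out lower numbers stand for a stronger effect and higher numbers for a weaker effect at the one concentration tested), compound 1 gives 91%, whereas compound 2 `COc1ccc(-c2cc(/C=C/C(=O)c3ccc(N)cc3)[nH]n2)cc1` gives 72% in this assay, a gap beyond the scatter. Within the data shown here, no step between measured compounds that differ in a single place has been recorded. Compound 3 `COc1ccc(C(=O)/C=C/c2cc(-c3cc(OC)c(OC)c(OC)c3)n[nH]2)cc1OC` remains to be measured. Against compound 1 the change is 3,4-dimethoxyphenyl in place of 3,4-dichlorophenyl on a carbonyl carbon. With no comparable change measured, only a small shift toward lower numbers is expected, probably within the scatter, as a number 9 percentage points lower from compound 1 to compound 3 (within the scatter). For compound 3 in this assay the estimate is 82%, with a range from 60% to 100%.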

Compound 3, a percentage reported as activity, at one concentration (the size of the read-out at that concentration, not a potency): 70%
Estimate against measurement, compound 3: 12 percentage points above; the measured number falls inside the stated range.
By their numbers in this assay, from the lowest: compounds 3 and 2 (each within the scatter of the next); then compound 1.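

On a carbonyl carbon, 3,4-dimethoxyphenyl in place of 3,4-dichlorophenyl gives a number 21 percentage points lower from compound 1 to compound 3 (beyond the scatter) in this assay. Within the data shown here, this is the only single-place step, and it shows that the read-out at this position responds to the aryl group carried there, with a modest step beyond the scatter. Nothing at hand accounts for the shift.

The compounds shown leave open whether the step needs both methoxy groups or whether a plain phenyl or 3,4-dihydroxyphenyl would read alike. From the compounds shown here alone, whether the same change holds on a different core also stays open.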